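Spirooxindole analogs on L02 cells: a triazole aryl swap

A few compounds are considered here, and "the series" means these few. Any claim that something is new, unique, unknown or untested is made for them only; others in the source may bear on it.

Going by the values given here, compound 2 `N#CC1=C(N)Oc2c(N)cc3nc4ccccc4nc3c2C12C(=O)N(Cc1cnnn1-c1ccccc1Br)c1ccccc12` gives 29200 nM in an ADME assay on L02 cells (Homo sapiens) for antiproliferative activity, read by MTT assay, with a stated time of 48 h (on this read-out lower numbers stand for stronger inhibition and higher numbers for weaker inhibition), the only number so far in this set. Compound 1 `Cc1cccc(-n2nncc2CN2C(=O)C3(C(C#N)=C(N)Oc4c(N)cc5nc6ccccc6nc5c43)c3ccccc32)c1` sits at a limit of the this assay read-out, > 50000 nM, so it carries no number. Between them the measured step of an at least 1.7-fold lower number from compound 1 to compound 2 (0.23 log units; that floor lies within the scatter) is the only one on record, and it rests on that limit (the limit of > 50000 nM in this assay, at which 1 of the 2 values shown sits), so its true size is not known beyond its floor.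

Compound 3 `N#CC1=C(N)Oc2c(N)cc3nc4ccccc4nc3c2C12C(=O)N(Cc1cnnn1-c1cccc(C(F)(F)F)c1)c1ccccc12` carries 3-(trifluoromethyl)phenyl in place of 2-bromophenyl on an aromatic nitrogen. This change sits at the same aromatic nitrogen that the measured step touches, but the measured step gives only a floor that lies within the scatter, so no direction can be taken from it for the new aryl group. The expectation is therefore a step of no clear size or direction beyond the scatter, with a real chance that this assay again reports only a limit.

Compound 3 is expected to give about 35000 nM in this assay, in a range from 12000 nM to 100000 nM. That estimate means a step of a 1.2-fold higher number from compound 2 to compound 3 (0.08 log units; within the scatter) from compound 2 to compound 3, expected to stay within the scatter.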

Compound 3, half-maximal inhibitory concentration: 38100 nM
Compound 3: the middle estimate sits 1.1-fold (0.04 log units) below what was measured; the range from low to high includes it.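

In this assay, going by these compounds alone, 3-(trifluoromethyl)phenyl in place of 2-bromophenyl on the aromatic nitrogen gives a 1.3-fold higher number from compound 2 to compound 3 (0.12 log units; within the scatter), the first step at this position that rests on two measured numbers rather than on a floor, and it does not separate the two aryl groups. Seen from the other side, trifluoromethyl in place of methyl on an aromatic carbon gives an at least 1.3-fold lower number from compound 1 to compound 3 (0.11 log units; that floor lies within the scatter), so this change, like the earlier step, shows no difference that can be told from the scatter. Compound 1 stands at a limit and not at a number, so the true size of that step remains unknown: the limit of > 50000 nM in this assay, at which 1 of the 3 values shown sits.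

The compounds shown leave open whether any substituent on this phenyl ring can move the read-out beyond the scatter, for example an amine or a carboxylic acid in place of the trifluoromethyl. They also leave open whether a longer chain in place of the aryl group on the aromatic nitrogen would change the number at all.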